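Changing the aryl substituent on the benzyl group once more

A few compounds are considered here, and "the series" means these few. Any claim that something is new, unique, unknown or untested is made for them only; others in the source may bear on it.

Of the compounds shown here, three have so far been measured in an assay on isolated protein for inhibition of protein deacetylase HDAC6 (Homo sapiens), read by fluorescence, with a stated time of 1 h, tested at 100 nM; a higher number here means more inhibition at the concentration tested (going by the name of the read-out), a lower number less inhibition. Compound 1 `O=C(/C=C/c1ccc(OCc2nc(C3CCN(Cc4ccc(Br)cc4)CC3)no2)cc1)NO` gives 58%. Compound 2 `Cc1cccc(CN2CCC(c3noc(CN(C)c4ncc(C(=O)NO)cn4)n3)CC2)c1` gives 54%, and compound 3 `CN(Cc1nc(C2CCN(Cc3ccccc3F)CC2)no1)c1ncc(C(=O)NO)cn1` gives 44%. Compound 3 thus holds the lowest of the three numbers: its nearest neighbour is compound 2, whose value lies within the scatter of its own, while compound 1 lies beyond the scatter above it.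

Compound 4 `CN(Cc1nc(C2CCN(Cc3ccc(C(F)(F)F)cc3)CC2)no1)c1ncc(C(=O)NO)cn1` has not yet been measured. It differs from compound 3 in one place only: 4-(trifluoromethyl)phenyl in place of 2-fluorophenyl on a saturated chain carbon bound to an amine nitrogen in a ring. For the measured compounds named here, the single measured step that bears on a change of this kind, a swap of the aromatic group on the saturated chain carbon bound to the amine nitrogen in the ring, is a number 10 percentage points lower from compound 2 to compound 3 (within the scatter), which stayed within the scatter. Going by the values given here, with only that one comparison to go on, no movement beyond the scatter is foreseen for the present swap either. The step expected from the change is therefore a number 1 percentage points higher from compound 3 to compound 4 (within the scatter), essentially flat. The estimate for compound 4 in this assay is 45%, with a likely range from 28% to 62%.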

Compound 4, a percentage reported as inhibition, at one concentration (the size of the read-out at that concentration, not a potency): 30%
Beside the measured number, compound 4's estimate is 15 percentage points above it; measured number inside the range.
By their numbers in this assay, from the lowest: compound 4; then compounds 3, 2 and 1 (each within the scatter of the next, the first and the last beyond it).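

In this assay, the aryl group on this saturated chain carbon is no longer a matter of indifference: 4-(trifluoromethyl)phenyl in place of 2-fluorophenyl gives a number 14 percentage points lower from compound 3 to compound 4 (beyond the scatter), and the same group in place of 3-methylphenyl gives a number 24 percentage points lower from compound 2 to compound 4 (beyond the scatter). For the compounds shown here, the one swap seen here before stayed within the scatter, so these are the first changes at this position that can be read as real differences, and they place 4-(trifluoromethyl)phenyl lowest of the three aryl groups carried by this shared core. No measurement at hand says why the number falls when this group enters.

The names of the groups show that each step alters both the substituent and where it sits on the aromatic ring, so the compounds shown cannot separate the trifluoromethyl group itself from its place on that ring. Also open, going by these compounds, is how an unsubstituted phenyl, or a phenyl carrying a methoxy group, an amine or a carboxylic acid, would read at this carbon in this assay.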